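The source may hold more compounds than are shown below. What is called first, only, known or untested is meant among the compounds shown, and "the series" means these compounds.

Compound 3 `C#Cc1cn([C@@H]2O[C@H](CO)[C@@H](O)[C@H]2O)c2ncnc(NC)c12` is an analogue of compound 1 `C#Cc1cn([C@@H]2O[C@H](CO)[C@@H](O)[C@H]2O)c2ncnc(N(C)C)c12`, differing only in that hydrogen replaces methyl on the ring-borne nitrogen. In a functional assay on HCT-116 cells (Homo sapiens), read by MTT assay, with a stated time of 72 h (a higher number here means a weaker inhibitor, a lower number a stronger inhibitor), compound 1 gives 180 nM. Compound 3, by contrast, reaches only a limit of this assay, > 20000 nM. That step, an at least 110-fold higher number from compound 1 to compound 3 (2.04 log units; beyond the scatter), is the one measured step shown. Compound 2 `O=c1[nH]cnc2c1c(-c1cccs1)cn2[C@@H]1O[C@H](CO)[C@@H](O)[C@H]1O`, which also carries thiophen-2-yl, likewise gives only a limit, > 20000 nM. Compound 4 `CNc1ncnc2c1c(-c1cccs1)cn2[C@@H]1O[C@H](CO)[C@@H](O)[C@H]1O` arises from compound 3 by the change (thiophen-2-yl in place of ethynyl on an aromatic carbon). Among the measured compounds shown here, no measured step covers this change; compound 3 already sits where it does because of the limit of > 20000 nM in this assay, at which 2 of the 3 values shown sit, so no movement beyond the scatter is expected, a step that the limit leaves unreadable from compound 3 to compound 4. Compound 4 is therefore estimated at 25000 nM, within 8000 nM to 80000 nM.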

Compound 4, half-maximal inhibitory concentration: > 20000 nM
Compound 4: a limit, no number (the forecaster's own chance of this, stated with the estimate: 75%); the middle value does not contradict the limit.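

Among the compounds shown here, compound 4 gives only a limit in this assay, > 20000 nM, and since compound 3 also sits at a limit, no step between them can be read. The compounds shown leave open what thiophen-2-yl in place of ethynyl does on a compound with a measurable value, such as compound 1.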